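A few compounds are considered here, and "the series" means these few. Any claim that something is new, unique, unknown or untested is made for them only; others in the source may bear on it.

Three compounds share one core and differ only in a group at its edge. In an ADME assay on the whole organism (serum, Rattus norvegicus) for protein binding (on this read-out higher numbers stand for a larger free fraction and lower numbers for a smaller free fraction), compound 1 `Cc1cc(-c2ccc(N3C(=O)C(O)=C(C(=O)C(C)(C)C)C3c3ccccc3OCCO)cc2)on1` gives "not determined" (no result reported). Compound 2 `CC(C)(C)C(=O)C1=C(O)C(=O)N(c2ccc(-c3ccoc3)cc2)C1c1ccccc1OCCO` gives "not determined" (no result reported) in this assay. Among the compounds with values here, compound 3 `CC(C)(C)C(=O)C1=C(O)C(=O)N(c2ccc(-c3ccsc3)cc2)C1c1ccccc1OCCO` provides the only number: in this assay compound 3 gives 0.002, a very small free fraction, meaning almost all of it is bound to serum protein. Compound 4 `CC(C)(C)C(=O)C1=C(O)C(=O)N(c2ccc(-c3cccs3)cc2)C1c1ccccc1OCCO` has not yet been measured. It differs from compound 3 in one place: thiophen-2-yl in place of thiophen-3-yl on an aromatic carbon. Within the data shown here, no measured pair of this kind is available to calibrate the change, and a swap between two isomers of the same ring is expected to move the free fraction by no more than the usual scatter. The expected step is no change at the digits printed from compound 3 to compound 4 (within the scatter). Compound 4 is therefore estimated to give 0.002 in this assay, within a range from 0.001 to 0.004.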

Compound 4, unbound fraction: 0.001
Compound 4: the middle estimate sits 2.0-fold (0.30 log units) above what was measured; the measured number falls inside the stated range.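

Within this assay, thiophen-2-yl in place of thiophen-3-yl gives a 2.0-fold lower number from compound 3 to compound 4 (0.30 log units; within the scatter), the first readable step at this position, and it shows that moving the attachment point within this ring leaves the two compounds indistinguishable. The steps to compound 1 and compound 2 cannot be read. Nothing here explains why the read-out behaves this way.

Still open, from the compounds shown here alone, is how far this position can shift the free fraction at all. A carboxylic acid or an amine in place of the thiophene ring might show whether any group here moves it beyond the scatter.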